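From diethylamino to dipropylamino on the saturated ring

The source may hold more compounds than are shown below. What is called first, only, known or untested is meant among the compounds shown, and "the series" means these compounds.

Three compounds sharing one core have numbers in a functional assay on the whole organism for antagonist activity, with Mus musculus as the target; a higher number here means that more compound is needed for the effect, a lower number that less compound is needed. Compound 1 `CCC(=O)N(c1ccc(Cl)c(Cl)c1)C1CCCC1O`, carrying hydroxy on a saturated ring carbon, gives 9 mg/kg. Compound 2 `CCC(=O)N(c1ccc(Cl)c(Cl)c1)C1CCCC1N`, carrying amino there, gives 0.8 mg/kg. Compound 3 `CCC(=O)N(c1ccc(Cl)c(Cl)c1)C1CCCC1N(CC)CC`, carrying diethylamino there, gives 0.03 mg/kg, the lowest of the three numbers.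

Compound 4 `CCCN(CCC)C1CCCC1N(C(=O)CC)c1ccc(Cl)c(Cl)c1` has not yet been measured. It carries dipropylamino in place of diethylamino on a saturated ring carbon.

The nearest measured step is a 27-fold lower number from compound 2 to compound 3 (1.43 log units; beyond the scatter), which is large and beyond the scatter. The other two are also large and beyond the scatter: an 11-fold lower number from compound 1 to compound 2 (1.05 log units; beyond the scatter) and a 300-fold lower number from compound 1 to compound 3 (2.48 log units; beyond the scatter). All three lower the number, but each replaces hydroxy or amino, and none compares two dialkylamino groups. Among the compounds with values here, their size therefore does not carry over directly, and the data hold no example of lengthening these chains. A far smaller change is expected in this assay, most likely toward a somewhat higher number, though a result within the scatter would not surprise. The estimated change is a 2.0-fold higher number from compound 3 to compound 4 (0.30 log units; within the scatter). For compound 4 the expected value is 0.06 mg/kg, with an estimated range of 0.015 mg/kg to 0.3 mg/kg.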

Compound 4, dose for half-maximal effect: 0.1 mg/kg
Estimate against measurement, compound 4: 1.7-fold (0.22 log units) below; the range from low to high includes it.
By their numbers in this assay, from the lowest: compound 3; then compound 4; then compound 2; then compound 1.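

In this assay, this is the first comparison of two dialkylamino groups on this saturated ring carbon, and it gives a 3.3-fold higher number from compound 3 to compound 4 (0.52 log units; beyond the scatter): lengthening both chains from ethyl to propyl raises the number by a modest step beyond the scatter, leaving diethylamino the lowest of the four groups shown. The longer chains still keep most of the advantage over the smaller or non-amine groups at this position, with an 8.0-fold lower number from compound 2 to compound 4 (0.90 log units; beyond the scatter) and a 90-fold lower number from compound 1 to compound 4 (1.95 log units; beyond the scatter), so dipropylamino remains well placed in the order of the series, and the step between the two dialkylamino groups is small beside the step from amino or hydroxy to either of them. No measurement in hand bears on why the number shifts with chain length.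

The compounds shown leave open whether dimethylamino, or a ring amine such as pyrrolidine or piperidine at this carbon, would give a number below that of compound 3 in this assay. On these data alone, whether dibutylamino would continue the rise is equally open, since diethylamino and dipropylamino together supply a single step and not a trend.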